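This account rests on a few compounds, and the source may have more. Where it says the series, first, only, none or still open, it means among the compounds named here.

Compound 1 `Nc1cc(N)c2nc(-c3ccccc3)c(NCc3ccc(Cl)c(Cl)c3)nc2c1` and compound 2 `COc1ccc(CNc2nc3cc(N)cc(N)c3nc2-c2ccccc2)cc1OC` share one core and differ only in the group carried on the saturated chain carbon bound to the ring nitrogen. In a functional assay on SF-539 cells (Homo sapiens) for inhibition, read by sulforhodamine B assay, with a stated time of 48 h (a higher number here means that more compound is tolerated, a lower number that less compound is tolerated), compound 1 gives 83200 nM. In this assay compound 2 gives a limit of the assay, < 100000 nM. The step that the limit leaves unreadable from compound 1 to compound 2 cannot be read in size because of the limit of < 100000 nM in this assay, at which 1 of the 2 values shown sits. Compound 3 `COc1cc(CNc2nc3cc(N)cc(N)c3nc2-c2ccccc2)cc(OC)c1OC` adds one change to compound 2: methoxy in place of hydrogen on an aromatic carbon. Going by the values given here, no measured step resembles this change, so for compound 3 in this assay a step that the limit leaves unreadable from compound 2 to compound 3 within the scatter is expected. Compound 3 is expected to give 80000 nM, between 30000 nM and 150000 nM.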

Compound 3, concentration lethal to 50% of the cells: 26900 nM
Compound 3: middle estimate off by 3.0-fold (0.47 log units), on the high side; the measured number lies below the stated range.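

No new step can be read between compound 2 and compound 3, because compound 2 carries only a limit: the limit of < 100000 nM in this assay, at which 1 of the 3 values shown sits. Still open, on these data alone, is how far methoxy in place of hydrogen on an aromatic carbon shifts the value in this assay here.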